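Three shikonin esters and ethers, and a longer chain

The compounds below may be only part of what the source reports. "The series", "measured", "known", "first", "only" and "open" are said of these compounds alone.

Measured in a functional assay on HeLa cells (Homo sapiens) for cytotoxicity, read by MTT assay; a higher number here means a weaker inhibitor, a lower number a stronger inhibitor:
compound 1, `CC[C@](C)(O)CC(=O)O[C@H](CC=C(C)C)C1=CC(=O)c2c(O)ccc(O)c2C1=O`: 30200 nM
compound 2, `CC(C)=CC[C@@H](OCC(C)O)C1=CC(=O)c2c(O)ccc(O)c2C1=O`: 24700 nM
compound 3, `CC(=O)OC(C)CO[C@H](CC=C(C)C)C1=CC(=O)c2c(O)ccc(O)c2C1=O`: 40100 nM

Compound 1 stands second highest of the three numbers; its nearest neighbour is compound 2, and the gap between them is a 1.2-fold lower number from compound 1 to compound 2 (0.09 log units; within the scatter), while toward compound 3 the gap is a 1.3-fold higher number from compound 1 to compound 3 (0.12 log units; within the scatter). Compound 2 and compound 3 differ from each other by a 1.6-fold higher number from compound 2 to compound 3 (0.21 log units; within the scatter). None of these three steps reaches beyond the scatter, so the three measured compounds cannot be ordered in this assay.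

Compound 4, `CCCCCCC(C)(O)CC(=O)O[C@H](CC=C(C)C)C1=CC(=O)c2c(O)ccc(O)c2C1=O`, keeps the core and the ester of compound 1 and differs only in the chain: 1-hydroxy-1-methylheptyl in place of 1-hydroxy-1-methylpropyl on a saturated chain carbon bound to a carbonyl carbon. Within the data shown here, no measured step changes that chain alone; the steps from compound 1 to compound 2 and to compound 3, which exchange the whole ester for an ether, stayed within the scatter. Compound 4 is therefore expected to show no step beyond the scatter, a 1.1-fold lower number from compound 1 to compound 4 (0.03 log units; within the scatter), and its estimated value in this assay is 28000 nM, within 12000 nM to 65000 nM.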

Compound 4, half-maximal inhibitory concentration: > 100000 nM
Compound 4 was reported as a limit (the forecaster's own chance of this, stated with the estimate: 5%); middle value at least 3.5-fold (0.55 log units) from the limit.
By their numbers in this assay, from the lowest: compounds 2, 1 and 3 (each within the scatter of the next). At a limit, above all of these: compound 4.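

In this assay, among these compounds, the change to 1-hydroxy-1-methylheptyl on a saturated chain carbon bound to a carbonyl carbon gives an at least 3.3-fold higher number from compound 1 to compound 4 (0.51 log units; beyond the scatter) and is the first step in this set to pass beyond the scatter, which the exchanges of the whole ester for an ether did not do. Compound 4 reads > 100000 nM and this is a limit of the assay, not a number. From the compounds shown here alone, in this single pair, then, the length of the chain at this position matters more than the ester-to-ether exchanges did, while the full size of the step stays unknown: the limit of > 100000 nM in this assay, at which 1 of the 4 values shown sits.

Going by these compounds, what a chain of intermediate length, or an amine or a carboxylic acid at the end of this chain, would do at this position remains open. Also open, on these data alone, is whether the same longer chain would act alike on an ether such as compound 2.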